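Ring substitution pattern on the benzoic acid end

The source may report more compounds than this note shows. Statements on the series, on what has been measured and on what is new or still open speak of the compounds shown alone.

Measured compounds in an assay on HEK293 cells for positive allosteric modulation of metabotropic glutamate receptor 2 (Rattus norvegicus), read by thallium flux, with a stated time of 2.5 min; on this read-out higher numbers stand for an effect only at larger amounts of compound and lower numbers for an effect already at smaller amounts:
compound 1 `Cc1c(OCCCCOc2ccc(C(=O)O)cc2)ccc(C(=O)CC(C)C)c1O` gives 122 nM
compound 2 `Cc1ccc(C(=O)O)cc1OCCCCOc1ccc(C(=O)CC(C)C)c(O)c1C` gives 454 nM
compound 3 `Cc1c(OCCCCOc2ccc(C(=O)O)c(Cl)c2)ccc(C(=O)CC(C)C)c1O` gives 151 nM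

Compound 3 lies within the scatter of compound 1 and stands apart from compound 2, which has the higher number of the three by a margin beyond the scatter. The new entry, compound 4 `Cc1c(OCCCCOc2ccc(F)c(C(=O)O)c2)ccc(C(=O)CC(C)C)c1O`, differs from compound 3 in one place: 3-carboxy-4-fluorophenyl in place of 4-carboxy-3-chlorophenyl on an oxygen on a saturated carbon.

Going by the values given here, two measured steps bear on this change. The step of a 1.2-fold higher number from compound 1 to compound 3 (0.09 log units; within the scatter) shows that a halogen on the ring carrying the acid leaves the number unchanged. The step of a 3.7-fold higher number from compound 1 to compound 2 (0.57 log units; beyond the scatter) shows that naming the carboxy group at another place on that ring, together with a small substituent, raises the number modestly. The change to compound 4 combines both elements, so a modest rise in this assay is expected rather than none, with the halogen part expected to contribute little; the expected step is a 2.3-fold higher number from compound 3 to compound 4 (0.37 log units; beyond the scatter). Compound 4 is therefore estimated at 350 nM, with a range of 150 nM to 900 nM.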

Compound 4, half-maximal effective concentration: 153 nM
Compound 4: the middle estimate sits 2.3-fold (0.36 log units) above what was measured; measured number inside the range.
By their numbers in this assay, from the lowest: compounds 1, 3 and 4 (each within the scatter of the next); then compound 2.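

In this assay, 3-carboxy-4-fluorophenyl in place of 4-carboxy-3-chlorophenyl gives no readable change (a 1.0-fold higher number from compound 3 to compound 4 (0.01 log units; within the scatter)), and the same holds for 3-carboxy-4-fluorophenyl in place of 4-carboxyphenyl (a 1.3-fold higher number from compound 1 to compound 4 (0.10 log units; within the scatter)), so this position accepts a different carboxy arrangement together with a different halogen. The separation of compound 2 therefore does not extend to every relocated carboxy group: 3-carboxy-4-fluorophenyl in place of 5-carboxy-2-methylphenyl gives a step beyond the scatter (a 3.0-fold lower number from compound 2 to compound 4 (0.47 log units; beyond the scatter)). No measurement shown here gives a reason for these numbers.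

Open, as far as these compounds go, is whether the methyl group or the carboxy arrangement in 5-carboxy-2-methylphenyl accounts for the separation of compound 2, and whether 3-carboxyphenyl without fluorine matches compound 4. Also open, from the compounds shown here alone, is whether a tetrazole or a primary amide can stand in for the carboxylic acid on this ring.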